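A methoxy group gives way to hydrogen

The compounds below may be only part of what the source reports. "The series", "measured", "known", "first", "only" and "open" are said of these compounds alone.

Measured so far in a physicochemical assay for lipophilicity; on this read-out lower numbers stand for lower lipophilicity and higher numbers for higher lipophilicity
- compound 1 `COc1cc(O)c(C(=O)/C=C/c2cc(OC)c(OC)c(OC)c2)cc1OC` (3.5)
- compound 2 `COc1ccc(C(=O)/C=C/c2ccc(OC)c(OC)c2)c(O)c1` (3.53)

Compound 1 (3.5) stands within the usual scatter of compound 2 (3.53), so the two numbers cannot be told apart, although the two structures differ in more than one place. The next step leads to compound 3 `COc1ccc(O)c(C(=O)/C=C/c2cc(OC)c(OC)c(OC)c2)c1`, which has not yet been measured. The change is hydrogen in place of methoxy on an aromatic carbon with hydrogen in place of methoxy on an aromatic carbon, ortho to a methoxy group, meta to a hydroxy group and para to a large group. For the measured compounds named here, no measured pair isolates this change. In this assay no shift beyond the scatter is expected, with no firm direction. The expected step of a number 0.05 log units higher from compound 1 to compound 3 (within the scatter) is therefore small. For compound 3 the estimate is 3.55 within an expected range of 3.2 to 3.9 in this measurement.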

Compound 3, partition coefficient: 3.47
For compound 3 the middle estimate is 0.08 log units above the measured one; low and high end bracket the measured number.
By their numbers in this assay, from the lowest: compounds 3, 1 and 2 (each within the scatter of the next).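

Compound 1 and compound 3 form the first pair shown that differs in one place, so this change can now be read alone, which compound 1 and compound 2 did not allow. In this assay, hydrogen in place of methoxy on this aromatic carbon, ortho to a methoxy group, meta to a hydroxy group and para to a large group, gives a number 0.03 log units lower from compound 1 to compound 3 (within the scatter). No other data shown bear on the reason for this result.

Among the compounds shown, only methoxy and hydrogen can be compared at this position, so it stays open whether an amine or a carboxylic acid there would give a step beyond the scatter. As far as these compounds go, it also stays open whether the same exchange elsewhere on the core of compound 1 would give a similar step.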